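The compounds below may be only part of what the source reports. "The series", "measured", "known", "first", "only" and "open" are said of these compounds alone.

Measured compounds in the series:

compound 1 `O=C1OCCN1c1cc(C(F)(F)F)ccc1[C@H]1CCOc2cc(S(=O)(=O)Nc3nccs3)ccc21`, in a physicochemical assay for lipophilicity (a higher number here means a more lipophilic compound, a lower number a more polar compound), compound 1 gives 2.1
compound 2 `Cn1nccc1-c1cc(C(F)(F)F)ccc1[C@H]1CCOc2cc(S(=O)(=O)Nc3nccs3)ccc21`, in this assay compound 2 gives 2.2

Compound 2 and compound 1 share the sulfonamide on the thiazole and differ only on an aromatic carbon of the core, where compound 2 carries 1-methyl-1H-pyrazol-5-yl in place of the 2-oxo-1,3-oxazolidin-3-yl of compound 1. For the measured compounds named here, the only measured step, a number 0.10 log units higher from compound 1 to compound 2 (within the scatter), lies within the scatter, so the two numbers show no separation; compound 2 has compound 1 as its only neighbour.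

The next compound, compound 3 `Cn1nccc1-c1cc(C(F)(F)F)ccc1[C@H]1CCOc2cc(S(=O)(=O)Nc3ccc(F)cn3)ccc21`, keeps the 1-methyl-1H-pyrazol-5-yl of compound 2 and changes the sulfonamide nitrogen instead: 5-fluoropyridin-2-yl in place of 1,3-thiazol-2-yl on a sulfonamide nitrogen.

Going by the values given here, no measured step touches the sulfonamide nitrogen; the single step in hand concerns another place and is itself within the scatter, so it gives no direct guide. What remains is the counted difference: a group of seven heavy atoms with one acceptor enters for one of five heavy atoms with two acceptors. On that basis a modest step upward in this assay is expected, a number 0.30 log units higher from compound 2 to compound 3 (within the scatter), though it may prove to stay within the scatter. Compound 3 is estimated at 2.5, with a range from 2.1 to 2.9.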

Compound 3, distribution coefficient: 3.8
The estimate for compound 3 lay 1.30 log units below the measured number; measured number above the stated range.
By their numbers in this assay, from the lowest: compounds 1 and 2 (each within the scatter of the next); then compound 3.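

In this assay, for the compounds shown here, the sulfonamide nitrogen is the first place where a single change moves the number beyond the scatter: 5-fluoropyridin-2-yl in place of 1,3-thiazol-2-yl gives a number 1.60 log units higher from compound 2 to compound 3 (beyond the scatter) while the only earlier step, on an aromatic carbon of the core, reads a number 0.10 log units higher from compound 1 to compound 2 (within the scatter) and shows no separation. This change combines two differences in one step, since a five-membered aromatic ring with 2 hetero atoms leaves and a six-membered aromatic ring with 1 hetero atom enters, carrying a fluorine. Nothing available bears on why the step is this large.

Still open, going by these compounds, is how much of the step belongs to the change of ring and how much to the fluorine, a split that pyridin-2-yl without the fluorine on the same sulfonamide nitrogen would address. Also open, on these data alone, is whether the step keeps its size with 2-oxo-1,3-oxazolidin-3-yl on the core rather than 1-methyl-1H-pyrazol-5-yl.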